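A few compounds are considered here, and "the series" means these few. Any claim that something is new, unique, unknown or untested is made for them only; others in the source may bear on it.

Of the compounds shown here, three have so far been tested in a functional assay on HeLa cells (Homo sapiens) for cytotoxicity, read by cell counting, with a stated time of 4 days; a lower number here means a stronger inhibitor, a higher number a weaker inhibitor. Compound 1 `Nc1cccc(/C=C2\SC(=O)N(Cc3ccc(F)cc3)C2=O)c1` gives 86000 nM. Compound 2 `Nc1cccc(/C=C2\SC(=O)N(Cc3ccccc3)C2=O)c1` reaches only a limit in this assay, reported as > 250000 nM. Compound 3 `C=C(Br)C(=O)Nc1cccc(/C=C2\SC(=O)N(Cc3ccc(F)cc3)C2=O)c1` gives 800 nM, the lowest number among those measured. Within this set, the change hydrogen in place of fluoro on an aromatic carbon brings an at least 2.9-fold higher number from compound 1 to compound 2 (0.46 log units; beyond the scatter), a step bounded by the limit of > 250000 nM in this assay, at which 1 of the 3 values shown sits. The change (1-bromoethenyl)carbonyl in place of hydrogen on a nitrogen on an aromatic ring brings a 110-fold lower number from compound 1 to compound 3 (2.03 log units; beyond the scatter). Compound 4 `C=C(Br)C(=O)Nc1cccc(/C=C2\SC(=O)N(Cc3ccccc3)C2=O)c1` has not yet been measured; it differs from compound 3 by hydrogen in place of fluoro on an aromatic carbon, and this is the same change that separates compound 1 from compound 2, made at the same place. An a 3.8-fold higher number from compound 3 to compound 4 (0.57 log units; beyond the scatter) is expected, resting on an at least 2.9-fold higher number from compound 1 to compound 2 (0.46 log units; beyond the scatter). Compound 4 is therefore expected to give about 3000 nM in this assay, most likely between 1200 nM and 10000 nM.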

Compound 4, half-maximal inhibitory concentration: 1400 nM
Beside the measured number, compound 4's estimate is 2.1-fold (0.33 log units) above it; measured number inside the range.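

Putting hydrogen in place of fluoro, which turns 4-fluorobenzyl into benzyl, gives a 1.8-fold higher number from compound 3 to compound 4 (0.24 log units; within the scatter), so this assay does not separate these two compounds. This does not show whether the change has the same size on both cores: the same change on two cores in this assay, an at least 2.9-fold higher number (0.46 log units; beyond the scatter) from compound 1 to compound 2 and a 1.8-fold higher number (0.24 log units; within the scatter) from compound 3 to compound 4; the limit leaves it open whether they differ The (1-bromoethenyl)carbonyl change, which brings an at least 170-fold lower number from compound 2 to compound 4 (2.25 log units; beyond the scatter), is large on both cores, but its exact size on the second core remains unknown: the same change on two cores in this assay, a 110-fold lower number (2.03 log units; beyond the scatter) from compound 1 to compound 3 and an at least 170-fold lower number (2.25 log units; beyond the scatter) from compound 2 to compound 4; the limit leaves it open whether they differ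

The compounds shown leave open whether a chloro or methoxy group in place of fluoro would also give a similar result. They also leave open what a simple acetyl group on that nitrogen would give in place of (1-bromoethenyl)carbonyl.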